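The source may hold more compounds than are shown below. What is called first, only, known or untested is meant among the compounds shown, and "the series" means these compounds.

In an ADME assay on microsomes (Homo sapiens) for metabolic stability (on this read-out lower numbers stand for a shorter-lived compound and higher numbers for a longer-lived compound), compound 1 (`O=C(C1CCC1)N1N=CCC1c1ccccc1`) gives 1.38 h. Compound 2 (`CC(C)(CO)C(=O)N1N=CCC1c1ccccc1`) gives > 1.5 h, which is a limit of the assay and not a number. Compound 2 therefore stands at the limit of > 1.5 h in this assay, at which 1 of the 2 values shown sits, and its true half-life is not known.

The change to compound 3 (`O=C(C1CCCCC1)N1N=CCC1c1ccccc1`) is cyclohexyl in place of 1-(hydroxymethyl)-1-methylethyl on a carbonyl carbon. Among the measured compounds shown here, one measured step bears on this change, an at least 1.0-fold higher number from compound 1 to compound 2 (0.03 log units; that floor lies within the scatter), which swapped the same 1-(hydroxymethyl)-1-methylethyl for cyclobutyl at that place. As far as these compounds go, it gives only a floor, so the size of any effect of that group remains open.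

Compound 3 has a ring of carbon only at this place, as does compound 1, which makes compound 1 at 1.38 h the closest guide. A value near that of compound 1 is expected, with no shift beyond the scatter in this assay. The expected change is an at least 1.3-fold lower number from compound 2 to compound 3 (0.13 log units; that floor lies within the scatter). The estimate for compound 3 is 1.1 h, with an expected range of 0.5 h to 1.5 h.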

Compound 3, half-life: 0.617 h
The estimate for compound 3 lay 1.8-fold (0.25 log units) above the measured number; measured number inside the range.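

In this assay, this place on the carbonyl carbon does not treat carbon-only rings alike: a 2.2-fold lower number from compound 1 to compound 3 (0.35 log units; beyond the scatter), with cyclohexyl in place of cyclobutyl, so a change within that ring type alone gives a modest step beyond the scatter. Replacing 1-(hydroxymethyl)-1-methylethyl with cyclohexyl gives an at least 2.4-fold lower number from compound 2 to compound 3 (0.38 log units; beyond the scatter), and this floor lies beyond the scatter, whereas the floor of the earlier step at this place, an at least 1.0-fold higher number from compound 1 to compound 2 (0.03 log units; that floor lies within the scatter), did not separate cyclobutyl from 1-(hydroxymethyl)-1-methylethyl. As far as these compounds go, the full size of the newer step stays unknown, since the value of compound 2 is a limit and not a number: the limit of > 1.5 h in this assay, at which 1 of the 3 values shown sits.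

With only cyclobutyl and cyclohexyl among the rings, the compounds shown cannot tell whether the half-life follows ring size in a steady way or whether cyclohexyl alone stands apart, a question that cyclopentyl or cycloheptyl at this place would address. They also leave open whether the gap between compound 2 and compound 3 goes with the hydroxyl or with the open chain, which tert-butyl or hydroxycyclohexyl on the same carbonyl carbon would help separate.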